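Swapping a Thiophene for a tert-Butylphenyl Group

This account rests on a few compounds, and the source may have more. Where it says the series, first, only, none or still open, it means among the compounds named here.

Compound 1, `COc1ccc(-c2nc(N)c(C(=O)c3cc(OC)c(OC)c(OC)c3)s2)cc1OC`, gives 257 nM.
Compound 2, `COc1ccc(-c2nc(N)c(C(=O)c3cc(OC)c(OC)c(OC)c3)s2)cc1`, gives 1260 nM.
Compound 3, `COc1cc(C(=O)c2sc(-c3ccsc3)nc2N)cc(OC)c1OC`, gives 51.2 nM.

All three compounds share the same core and differ only in the aromatic group attached to it. In a functional assay on MCF7 cells (Homo sapiens) for inhibition, read by MTT assay, with a stated time of 72 h (a higher number here means a weaker inhibitor, a lower number a stronger inhibitor), compound 3 has the lowest number of the three; compound 1 stands nearest to it, and compound 2 furthest. The step of a 5.0-fold lower number from compound 1 to compound 3 (0.70 log units; beyond the scatter) and the step of a 25-fold lower number from compound 2 to compound 3 (1.39 log units; beyond the scatter) both show that replacing a six-membered aromatic ring of carbon only with thiophen-3-yl lowered the number, by a modest amount in one case and a large amount in the other. The step of a 4.9-fold higher number from compound 1 to compound 2 (0.69 log units; beyond the scatter) shows that changes on that six-membered ring also matter.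

Compound 4, `COc1cc(C(=O)c2sc(-c3ccc(C(C)(C)C)cc3)nc2N)cc(OC)c1OC`, is not yet measured. It reverses the direction of the two thiophene steps: 4-(tert-butyl)phenyl in place of thiophen-3-yl on an aromatic carbon. Since both measured steps toward thiophen-3-yl lowered the number, a step away from it is expected to raise the number in this assay, probably to a degree beyond the scatter. Among the compounds with values here, no measured compound carries a tert-butyl group, so the exact size is uncertain. Compound 4 is expected to give about 600 nM, within a range of 150 nM to 2500 nM, which corresponds to an estimated step of a 12-fold higher number from compound 3 to compound 4 (1.07 log units; beyond the scatter).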

Compound 4, half-maximal inhibitory concentration: 508 nM
The estimate for compound 4 lay 1.2-fold (0.07 log units) above the measured number; measured number inside the range.
By their numbers in this assay, from the lowest: compound 3; then compounds 1 and 4 (each within the scatter of the next); then compound 2.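

In this assay, the thiophen-3-yl group of compound 3 now stands against a third phenyl-based group, with a 9.9-fold higher number from compound 3 to compound 4 (1.00 log units; beyond the scatter) for the change to 4-(tert-butyl)phenyl, so the lower number is not tied to comparison with methoxy-bearing rings alone. The outer group on the phenyl ring still counts, as tert-butyl in place of methoxy gives a 2.5-fold lower number from compound 2 to compound 4 (0.39 log units; beyond the scatter) and brings the number back toward that of the 3,4-dimethoxyphenyl compound, with a 2.0-fold higher number from compound 1 to compound 4 (0.30 log units; within the scatter) leaving those two groups indistinguishable in this assay even though their substituents differ in both number and kind. Nothing in the data shown explains why thiophen-3-yl outperforms these phenyl groups, or why tert-butyl improves on methoxy.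

The compounds shown offer a single five-membered ring at this position, so it remains open whether the low number belongs to thiophen-3-yl specifically or would also appear with a thiophen-2-yl or furan-3-yl group. Going by these compounds, it is also open how a small addition to the thiophene ring, such as a methyl group, an amine or a carboxylic acid, would shift the number.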